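This account rests on a few compounds, and the source may have more. Where it says the series, first, only, none or still open, it means among the compounds named here.

Measured compounds:

Compound 1, `OC[C@H]1O[C@@H](OCCc2ccc(O)c(Br)c2)[C@H](O)[C@@H](O)[C@@H]1O`, which in a functional assay, with a stated time of 30 min (on this read-out lower numbers stand for stronger inhibition and higher numbers for weaker inhibition), gives a limit of the assay, > 100000 nM.

Compound 2, `COc1cc(CCO[C@@H]2O[C@H](CO)[C@@H](O)[C@H](O)[C@H]2O)cc(OC)c1O`, which in this assay gives 61700 nM.

For the measured compounds named here, compound 2 carries the only numerical value in this assay; the other entry is a limit of the assay rather than a number, as the limit of > 100000 nM in this assay, at which 1 of the 2 values shown sits, records. Going by the values given here, no step between two measured compounds is available, so the scale of change that a single alteration can bring in this assay is not known from these data.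

Compound 3, `COc1cc(CCO[C@@H]2O[C@H](CO)[C@H](O)[C@H](O)[C@H]2O)cc(OC)c1O`, is the compound still to be measured. Compared with compound 2, (the two compounds have the same atoms and bonds and differ only in configuration as drawn: 1 of 5 stereo elements differ; a stereocentre at a saturated ring carbon is drawn S in compound 2 and R in compound 3). The compounds share every atom and bond and differ only in the drawn configuration at one saturated ring carbon. Among the compounds with values here, with no measured step to guide the direction, the step from compound 2 to compound 3 in this assay is expected to stay within the usual scatter, a 1.0-fold lower number from compound 2 to compound 3 (0.01 log units; within the scatter). Compound 3 is therefore estimated at 60000 nM, within a range from 20000 nM to 200000 nM.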

Compound 3, half-maximal inhibitory concentration: 70100 nM
Beside the measured number, compound 3's estimate is 1.2-fold (0.07 log units) below it; measured number inside the range.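

For the compounds shown here, the first step that can be read in this assay is a 1.1-fold higher number from compound 2 to compound 3 (0.06 log units; within the scatter), so drawing this one saturated ring carbon as R rather than S gives a number that cannot be told apart from that of compound 2. The comparison isolates this single stereocentre, as nothing else in the two structures varies: the fact that compounds 2 and 3 differ only in the configuration as drawn Compound 1 still offers no number to compare, as its > 100000 nM is a limit of the assay.

As far as these compounds go, whether the other four stereo elements of the shared core would prove equally silent in this assay remains open, since only this one has been seen as a single step. Also open, from the compounds shown here alone, is how the read-out would respond if an amine or a carboxylic acid stood on the shared core, or if a longer chain replaced the link to the aromatic ring.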